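Acyl variation on the shared core

A few compounds are considered here, and "the series" means these few. Any claim that something is new, unique, unknown or untested is made for them only; others in the source may bear on it.

Measured in an assay on HEK293 cells for positive allosteric modulation of metabotropic glutamate receptor 5 (Homo sapiens), read by FLIPR, with a stated time of 1 h; a lower number here means that less compound is needed, a higher number that more compound is needed for the effect:
compound 1 `CCC(=O)N1CCc2nc(C#Cc3ccccc3)sc2C1`: > 10000 nM (this is a limit of the assay, not a number)
compound 2 `O=C(C1CC(F)C1)N1CCc2nc(C#Cc3ccccc3)sc2C1`: 85 nM
compound 3 `O=C(C1CCCC1)N1CCc2nc(C#Cc3ccccc3)sc2C1`: 19 nM

Compound 3 holds the lowest of the two numbers recorded in this assay; its nearest neighbour is compound 2, and the third value is only a limit (the limit of > 10000 nM in this assay, at which 1 of the 3 values shown sits). The steps measured so far all sit on the carbonyl carbon: an at least 110-fold lower number from compound 1 to compound 2 (2.07 log units; beyond the scatter) and an at least 520-fold lower number from compound 1 to compound 3 (2.72 log units; beyond the scatter) are large, a 4.5-fold lower number from compound 2 to compound 3 (0.65 log units; beyond the scatter) is modest. Replacing ethyl by a ring thus gives a large gain, and among rings the cyclopentyl gives the lower number.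

Compound 4 `O=C(CC1CCOCC1)N1CCc2nc(C#Cc3ccccc3)sc2C1` differs from compound 3 by (oxan-4-yl)methyl in place of cyclopentyl on a carbonyl carbon. Among the compounds with values here, this change introduces a methylene spacer and an oxygen-containing six-membered ring in place of the carbon-only five-membered ring; no measured step covers a spacer or a ring hetero atom, so the bearing of the existing steps is indirect. The steps show that the carbonyl substituent matters strongly, and that moving away from cyclopentyl has so far raised the number. A modest rise from compound 3 to compound 4 is therefore expected, a 3.7-fold higher number from compound 3 to compound 4 (0.57 log units; beyond the scatter), in this assay.

Compound 4 is estimated at 70 nM, with a range from 15 nM to 400 nM.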

Compound 4, half-maximal effective concentration: 470 nM
Compound 4: the middle estimate sits 6.7-fold (0.83 log units) below what was measured; the whole stated range lies below it.
By their numbers in this assay, from the lowest: compound 3; then compound 2; then compound 4. At a limit, above all of these: compound 1.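

In this assay, (oxan-4-yl)methyl on the carbonyl carbon gives a 25-fold higher number from compound 3 to compound 4 (1.39 log units; beyond the scatter), and the comparison with the fluorinated ring gives a 5.5-fold higher number from compound 2 to compound 4 (0.74 log units; beyond the scatter), so a ring on this carbonyl carbon does not by itself secure the low numbers of compound 2 and compound 3. Nor does the heavy-atom count set the order here: ethyl gives the highest reading, yet the 7 heavy atoms of (oxan-4-yl)methyl stand above the 5 of cyclopentyl, so compound 1 and compound 4 both go against any rule that a larger group gives a lower number. Some gain over ethyl remains, an at least 21-fold lower number from compound 1 to compound 4 (1.32 log units; beyond the scatter), a step that rests on a limit of the assay for compound 1 and not on a number: the limit of > 10000 nM in this assay, at which 1 of the 4 values shown sits.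

The step joins a methylene spacer and a ring oxygen in one change, and the compounds shown do not separate the two; cyclohexylmethyl or oxan-4-yl on the carbonyl carbon would each carry only one of them. Also open, as far as these compounds go, is where a ring amine such as piperidin-4-yl, or a longer chain such as butyl, would stand against cyclopentyl in this assay.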